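The source may hold more compounds than are shown below. What is called first, only, known or untested is meant among the compounds shown, and "the series" means these compounds.

Compound 1 `CCN(C(=O)c1cc(C)ccc1-n1nccn1)[C@@H](C)Cn1cc(-c2ccc(F)cn2)nn1` gives 22.8 nM in a functional assay on cells for antagonist activity at Orexin receptor type 2 (Homo sapiens), read by fluorescence and calcium flux, with a stated time of 30 min; on this read-out higher numbers stand for weaker inhibition and lower numbers for stronger inhibition.
Compound 2 `CCN(C(=O)c1cc(C)ccc1-n1nccn1)[C@@H](C)Cn1nnc(-c2ccc(F)cn2)n1` gives 17.9 nM in this assay.
Compound 3 `CCN(C(=O)c1cc(C)ccc1-n1nccn1)[C@@H](C)Cn1nnc(-c2ccc(F)cc2)n1` gives 2.57 nM in this assay.

Compound 3 stands lowest of these three numbers, so among them it is the strongest inhibitor. Compound 2 sits nearest to it, separated by a step of a 7.0-fold lower number from compound 2 to compound 3 (0.84 log units; beyond the scatter), which comes from exchanging one aryl ring for another on the triazole side of the molecule. Compound 1 lies furthest away, its number higher still than that of compound 2, and both gaps lie beyond the scatter.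

Compound 4 `CCN(C(=O)c1cc(C)ccc1-c1ncccn1)[C@@H](C)Cn1nnc(-c2ccc(F)cc2)n1` keeps everything in compound 3 except one ring on the shared core: pyrimidin-2-yl in place of 2H-1,2,3-triazol-2-yl on an aromatic carbon. Among the measured compounds shown here, the single measured step, from compound 2 to compound 3, concerns a different part of the molecule and says nothing about an exchange at this place. For the measured compounds named here, no step in hand therefore bears on the change from compound 3 to compound 4, and its effect in this assay can only be guessed. The step of a 1.6-fold higher number from compound 3 to compound 4 (0.19 log units; within the scatter) is expected to be small, within or barely beyond the scatter, in either direction. Compound 4 is estimated to give 4 nM, with a range from 1 nM to 16 nM.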

Compound 4, half-maximal inhibitory concentration: 36 nM
Compound 4: middle estimate off by 9.0-fold (0.95 log units), on the low side; measured number outside the range, above it.
By their numbers in this assay, from the lowest: compound 3; then compounds 2, 1 and 4 (each within the scatter of the next).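

The ring on the shared core, on an aromatic carbon ortho to a large group and para to a methyl group, is not a neutral place to make an exchange. In this assay, pyrimidin-2-yl in place of 2H-1,2,3-triazol-2-yl brings a 14-fold higher number from compound 3 to compound 4 (1.15 log units; beyond the scatter), a large step showing that this ring can move the number as well as the aryl ring at the other end of the molecule. The exchange replaces a five-membered aromatic ring with 3 hetero atoms by a six-membered one with 2, but nothing measured here explains the weaker inhibition or separates these differences.

On these data alone, it remains open whether a plain phenyl ring or a pyrazol-1-yl ring at this place would give a number close to that of compound 3 or close to that of compound 4. Also open, as far as these compounds go, is whether pyrimidin-2-yl would have a step of similar size when the 5-fluoropyridin-2-yl group of compound 2 stands in place of the 4-fluorophenyl group.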